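Swapping bromo for methyl on the aryl amine of compound 1

A few compounds are considered here, and "the series" means these few. Any claim that something is new, unique, unknown or untested is made for them only; others in the source may bear on it.

Compound 1 `COc1cc2ncnc(Nc3cccc(Br)c3)c2cc1OCCCCC(=O)Nc1ccc(S(N)(=O)=O)cc1` is the stronger of the two compounds measured here. In a functional assay on A-431 cells (Homo sapiens) for antiproliferative activity, read by MTT assay, with a stated time of 72 h (a lower number here means a stronger inhibitor, a higher number a weaker inhibitor), compound 1 gives 9750 nM, the lowest of the two numbers. Compound 2 `COc1ccc(Nc2ncnc3cc(OC)c(OCCCCC(=O)Nc4ccc(S(N)(=O)=O)cc4)cc23)cc1OC` gives 35400 nM in the same assay; the step of a 3.6-fold higher number from compound 1 to compound 2 (0.56 log units; beyond the scatter) comes from replacing the 3-bromophenyl with 3,4-dimethoxyphenyl on the amine nitrogen.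

Compound 3 `COc1cc2ncnc(Nc3cccc(C)c3)c2cc1OCCCCC(=O)Nc1ccc(S(N)(=O)=O)cc1` differs from compound 1 in a smaller way: methyl in place of bromo on an aromatic carbon. This is a methyl in place of bromo on the same 3-bromophenyl ring that was exchanged between compound 1 and compound 2, so that step is the only measured one that bears on it, and it bears only loosely, since it changed the whole ring rather than a single substituent. Because a 3.6-fold higher number from compound 1 to compound 2 (0.56 log units; beyond the scatter) showed that altering this ring weakens inhibition modestly, a smaller change at one position is expected to cost little, most likely a step within or just beyond the usual scatter toward a higher number.

Compound 3 is therefore expected to give 15000 nM in this assay, between 6000 nM and 40000 nM. The expected step of a 1.5-fold higher number from compound 1 to compound 3 (0.19 log units; within the scatter) is a small weakening.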

Compound 3, half-maximal inhibitory concentration: 7460 nM
Compound 3: middle estimate off by 2.0-fold (0.30 log units), on the high side; the range from low to high includes it.
By their numbers in this assay, from the lowest: compounds 3 and 1 (each within the scatter of the next); then compound 2.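

In this assay, putting methyl in place of bromo on this aromatic carbon gives a 1.3-fold lower number from compound 1 to compound 3 (0.12 log units; within the scatter) and so leaves the reading unchanged within the usual scatter: the assay does not separate compound 1 from compound 3. The earlier step replaced the whole ring, and it could not show whether the bromo itself was needed; the new comparison with the dimethoxy compound gives a 4.7-fold lower number from compound 2 to compound 3 (0.68 log units; beyond the scatter), so the gap to compound 2 persists when bromo is absent, and a ring carrying methyl at this place stands with the ring carrying bromo. No measurement available here explains why these two groups read alike or why the 3,4-dimethoxyphenyl compound gives a higher number.

From the compounds shown here alone, it remains open whether this carbon tolerates groups of a different kind, such as an amine, a carboxylic acid or a trifluoromethyl, or whether the match between bromo and methyl is limited to this pair. It is also open which of the two methoxy groups of compound 2 accounts for its higher number, a question that a ring carrying a single methoxy could address.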